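A Methanesulfonamido Group and Cytotoxicity in Liver Cells

The source may report more compounds than this note shows. Statements on the series, on what has been measured and on what is new or still open speak of the compounds shown alone.

Compound 1, `CC(C)CCc1cc(C2=NS(=O)(=O)c3ccccc3N2)c(O)c2ccccc12`: in an ADME assay on Huh-7 cells (Homo sapiens) for cytotoxicity (on this read-out lower numbers stand for higher toxicity in this test and higher numbers for lower toxicity in this test), compound 1 gives 37000 nM.
Compound 2, `CC(C)CCc1cc(C2=NS(=O)(=O)c3cc(NS(C)(=O)=O)ccc3N2)c(O)c2ccccc12`: compound 2 gives > 100000 nM, which is a limit of this assay and not a number.
Compound 3, `COc1c(C2=NS(=O)(=O)c3ccccc3N2)cc(CCC(C)C)c2ccccc12`: compound 3 gives 13000 nM.

Compound 2 differs from compound 1 by methanesulfonamido in place of hydrogen on an aromatic carbon. This change produced an at least 2.7-fold higher number from compound 1 to compound 2 (0.43 log units; beyond the scatter), so the result for compound 2 sits at the limit of > 100000 nM in this assay, at which 1 of the 3 values shown sits. Compound 3 differs from compound 1 by methyl in place of hydrogen on an oxygen on an aromatic ring, which brought a 2.8-fold lower number from compound 1 to compound 3 (0.45 log units; beyond the scatter).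

Compound 4, `COc1c(C2=NS(=O)(=O)c3cc(NS(C)(=O)=O)ccc3N2)cc(CCC(C)C)c2ccccc12`, has not yet been tested in this assay. It differs from compound 3 by methanesulfonamido in place of hydrogen on an aromatic carbon, the same change that turned compound 1 into compound 2, at the same place. That earlier change gave an at least 2.7-fold higher number from compound 1 to compound 2 (0.43 log units; beyond the scatter), and a similar outcome is therefore expected here, namely a 3.1-fold higher number from compound 3 to compound 4 (0.49 log units; beyond the scatter). Compound 4 is expected to give about 40000 nM, most likely between 15000 nM and 120000 nM, with a real chance that this assay reports only a limit.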

Compound 4, half-maximal cytotoxic concentration: 51000 nM
For compound 4 the middle estimate is 1.3-fold (0.11 log units) below the measured one, and the stated range covers the measured number.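

Methanesulfonamido in place of hydrogen on an aromatic carbon brought a 3.9-fold higher number from compound 3 to compound 4 (0.59 log units; beyond the scatter) in this assay, so the number rose on both cores shown. The direction of the change carried over from one core to the other, but two cores make no general rule, and whether the size carried over cannot be settled: the same change on two cores in this assay, an at least 2.7-fold higher number (0.43 log units; beyond the scatter) from compound 1 to compound 2 and a 3.9-fold higher number (0.59 log units; beyond the scatter) from compound 3 to compound 4; the limit leaves it open whether they differ. The reverse comparison, with methyl in place of hydrogen on the oxygen, gave an at least 1.9-fold lower number from compound 2 to compound 4 (0.29 log units; that floor lies within the scatter), and it too rests on the limit for compound 2, so it leaves the same question open for that change: the same change on two cores in this assay, a 2.8-fold lower number (0.45 log units; beyond the scatter) from compound 1 to compound 3 and an at least 1.9-fold lower number (0.29 log units; that floor lies within the scatter) from compound 2 to compound 4; the limit leaves it open whether they differ.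

The compounds shown leave open whether another group at the same place, such as an amine or a carboxylic acid, would shift the number in the same way. They also leave open whether methanesulfonamido would do the same on a core with a longer chain.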